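Hydroxy to amino on the acetamide chain, two cores

The source may report more compounds than this note shows. Statements on the series, on what has been measured and on what is new or still open speak of the compounds shown alone.

Measured so far:
Compound 1, `COc1ccc(C(=O)c2ccc(OC)c3c2C=CC(C)(C)O3)c(NC(=O)CO)c1`: 310 nM
Compound 2, `COc1ccc(C(=O)c2ccc(OC)c3c2C=CC(C)(C)O3)c(NC(=O)CN)c1`: 100 nM
Compound 3, `C=C(c1ccc(OC)cc1NC(=O)CO)c1ccc(OC)c2c1OC(C)(C)C=C2`: 40 nM

The three measured compounds were tested in a functional assay on HeLa cells (Homo sapiens) for antiproliferative activity, read by MTT assay, with a stated time of 48 h; a higher number here means a weaker inhibitor, a lower number a stronger inhibitor. Compound 1 has the structure `COc1ccc(C(=O)c2ccc(OC)c3c2C=CC(C)(C)O3)c(NC(=O)CO)c1` and, in this assay, compound 1 gives 310 nM. Compound 2, `COc1ccc(C(=O)c2ccc(OC)c3c2C=CC(C)(C)O3)c(NC(=O)CN)c1`, differs from it by one change, (amino in place of hydroxy on a saturated chain carbon bound to a carbonyl carbon), and the step is a 3.1-fold lower number from compound 1 to compound 2 (0.49 log units; beyond the scatter). Compound 3, `C=C(c1ccc(OC)cc1NC(=O)CO)c1ccc(OC)c2c1OC(C)(C)C=C2`, carries a different core; the difference between the two cores is not broken down here. In this assay compound 3 gives 40 nM, the lowest of the three numbers, and its steps to compound 2 and to compound 1 are both beyond the scatter.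

Compound 4, `C=C(c1ccc(OC)cc1NC(=O)CN)c1ccc(OC)c2c1OC(C)(C)C=C2`, has not yet been measured. It stands to compound 3 as compound 2 stands to compound 1: the change is amino in place of hydroxy on a saturated chain carbon bound to a carbonyl carbon, the same change as before, at the same place. Among the compounds shown this change occurs twice in all, so the only precedent is the single measured step from compound 1 to compound 2. Because that step was a 3.1-fold lower number from compound 1 to compound 2 (0.49 log units; beyond the scatter), a step of similar size is expected on the core of compound 3, namely a 2.7-fold lower number from compound 3 to compound 4 (0.43 log units; beyond the scatter). Within the data shown here, the expectation rests on one pair only, and the two cores differ, so a wider range is allowed than the one measured step alone would suggest. Compound 4 is therefore estimated at 15 nM in this assay, expected to lie between 6 nM and 40 nM.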

Compound 4, half-maximal inhibitory concentration: 120 nM
For compound 4 the middle estimate is 8.0-fold (0.90 log units) below the measured one; measured number outside the range, above it.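

In this assay, amino in place of hydroxy on a saturated chain carbon bound to a carbonyl carbon gives a 3.0-fold higher number from compound 3 to compound 4 (0.48 log units; beyond the scatter), so on this core the change runs the opposite way from the step on the core of compound 1. Set side by side, the two steps point in opposite directions, and the gap between them is larger than the scatter allows: the same change on two cores in this assay, a 3.1-fold lower number (0.49 log units; beyond the scatter) from compound 1 to compound 2 and a 3.0-fold higher number (0.48 log units; beyond the scatter) from compound 3 to compound 4, 9.3-fold (0.97 log units) apart, beyond the scatter of two such steps This shows that, across these two pairs, neither the size nor the direction of the change carries from one core to the other, so a step measured on one of these cores is no safe guide to the other, but it does not show why they part, and two pairs give no rule for any further core in the series.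

The compounds shown leave open which part of the difference between the two cores goes with the reversal, since the cores differ as wholes and that difference is not broken down here. Also open, as far as these compounds go, is how a substituted amine, a carboxylic acid or a longer chain, carried at the same place, would behave on each of the two cores.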